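Ortho Trifluoromethyl on the Pendant Phenyl of Compound 3

The source may hold more compounds than are shown below. What is called first, only, known or untested is meant among the compounds shown, and "the series" means these compounds.

Measured compounds:
compound 1 `COc1ccc(-n2cnc3cnc(-c4ccccc4C)cc32)cc1OC`: 69 nM
compound 2 `COc1ccc(-n2cnc3cnc(-c4cc(F)ccc4OC)cc32)cc1OC`: 1300 nM
compound 3 `Fc1ccc(-c2cc3c(cn2)ncn3-c2ccc(OC(F)F)cc2)cc1`: 10000 nM

In a functional assay on HL-60 cells (Homo sapiens) for activation, read by flow cytometry, with a stated time of 4 days (on this read-out lower numbers stand for an effect already at smaller amounts and higher numbers for an effect only at larger amounts of compound), compound 3 gives the highest of the three numbers, 10000 nM. Its nearest neighbour is compound 2, which gives 1300 nM, and the furthest is compound 1, which gives 69 nM. Compound 4 `Fc1ccc(-c2cc3c(cn2)ncn3-c2ccc(OC(F)F)cc2)c(C(F)(F)F)c1` differs from compound 3 by trifluoromethyl in place of hydrogen on an aromatic carbon. Going by the values given here, the only measured step that touches the same pendant phenyl ring is a 19-fold higher number from compound 1 to compound 2 (1.28 log units; beyond the scatter), a large rise in number when the substitution pattern on that ring was altered. That step shows the ring's substitution matters strongly in this assay, but it does not show which direction a trifluoromethyl ortho to a large group will take. Compound 3, carrying no substituent at that position, sits at the top of the range, which leaves room below. Compound 4 is therefore expected to show a modest fall in number, a 3.3-fold lower number from compound 3 to compound 4 (0.52 log units; beyond the scatter), with wide uncertainty. The estimate for compound 4 in this assay is 3000 nM, between 600 nM and 15000 nM.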

Compound 4, half-maximal effective concentration: 1500 nM
Estimate against measurement, compound 4: 2.0-fold (0.30 log units) above, and the stated range covers the measured number.
By their numbers in this assay, from the lowest: compound 1; then compounds 2 and 4 (each within the scatter of the next); then compound 3.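

In this assay, trifluoromethyl in place of hydrogen on an aromatic carbon, ortho to a large group and meta to a fluoro group, gives a 6.7-fold lower number from compound 3 to compound 4 (0.82 log units; beyond the scatter), a modest step. The earlier step on this ring only raised the number, whereas this one shows that adding a group here can lower it, so the position takes a group of four heavy atoms without a rise in number. Nothing available explains this fall.

As far as these compounds go, it remains open whether a methyl group, a chlorine atom, an amine or a carboxylic acid at this position would move the number in the same direction. From the compounds shown here alone, it is also open whether trifluoromethyl would have a similar effect on the ring of compound 1, which already carries a methyl group.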